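Thiophene to oxadiazolylphenyl: the upper limit likely holds

The source may hold more compounds than are shown below. What is called first, only, known or untested is meant among the compounds shown, and "the series" means these compounds.

Compound 1 `CC(C)N(Cc1cccc(OCCCCCC(=O)O)c1)C(=O)c1ccc(-c2cccc3ccccc23)cc1` — in an ADME assay on BJ cells (Homo sapiens) for cytotoxicity, read by CellTiter-Glo and resazurin assay, with a stated time of 72 h (a lower number here means that less compound is needed, a higher number that more compound is needed for the effect), compound 1 gives < 1.3 nM, a limit of the assay.
Compound 2 `CC(C)COc1cccc(-c2ccc(C(=O)N(Cc3cccc(OCCCCCC(=O)O)c3)C(C)C)cc2)c1` — compound 2 gives > 26000 nM, also a limit.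
Compound 3 `CC(C)N(Cc1cccc(OCCCCCC(=O)O)c1)C(=O)c1ccc(-c2ccsc2)cc1` — compound 3 gives > 26000 nM, again a limit.

Compound 3 therefore sits at the upper limit together with compound 2 (the limit of > 26000 nM in this assay, at which 2 of the 3 values shown sit), while compound 1 alone sits at the lower limit (the limit of < 1.3 nM in this assay, at which 1 of the 3 values shown sits). Compound 4 `Cc1nnc(-c2cccc(-c3ccc(C(=O)N(Cc4cccc(OCCCCCC(=O)O)c4)C(C)C)cc3)c2)o1` differs from compound 3 by 3-(5-methyl-1,3,4-oxadiazol-2-yl)phenyl in place of thiophen-3-yl on an aromatic carbon. Going by the values given here, no measured step covers this change directly: the step from compound 2 to compound 3 is unreadable (a step that the two limits leave unreadable from compound 2 to compound 3), while an at least 20000-fold higher number from compound 1 to compound 2 (4.30 log units; beyond the scatter) and an at least 20000-fold higher number from compound 1 to compound 3 (4.30 log units; beyond the scatter) show that both replacements of naphthalen-1-yl wiped out the effect seen with compound 1. Compound 2 likewise carries a substituted phenyl in place of naphthalen-1-yl and stays at the limit. Compound 4 is thus expected to remain at that limit, an expected step of a number no higher from compound 3 to compound 4 (the limit leaves the size open). The estimate for compound 4 is 26000 nM, ranging from 4000 nM to 30000 nM.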

Compound 4, half-maximal effective concentration: > 26000 nM
Compound 4 gave a limit, no number (the forecaster's own chance of this, stated with the estimate: 70%); the middle value lies on the limit itself.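

In this assay, swapping naphthalen-1-yl for the larger 3-(5-methyl-1,3,4-oxadiazol-2-yl)phenyl, with its two rings and three hydrogen-bond acceptors, does not keep the effect, giving an at least 20000-fold higher number from compound 1 to compound 4 (4.30 log units; beyond the scatter). So a third, quite different group at this place joins the other two replacements, in compound 2 and compound 3. All three values are limits, so the steps among these compounds cannot be read: the limit of > 26000 nM in this assay, at which 3 of the 4 values shown sit.

Going by these compounds, how far each lies beyond that limit stays open. So does whether any group other than naphthalen-1-yl gives an effect here, for example an amine in place of 5-methyl-1,3,4-oxadiazol-2-yl.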